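The source may report more compounds than this note shows. Statements on the series, on what has been measured and on what is new or still open speak of the compounds shown alone.

Series under review in a functional assay on PC-3 cells (Homo sapiens) for antiproliferative activity, read by MTT assay; on this read-out lower numbers stand for stronger inhibition and higher numbers for weaker inhibition:

- compound 1 `Cn1c(=O)c(=O)n(C2CCCC2)c2nc(N/N=C/c3ccccc3)ncc21`: 48200 nM
- compound 2 `Cn1c(=O)c(=O)n(C2CCCC2)c2nc(N/N=C/c3ccc(O)c(F)c3)ncc21`: 85200 nM
- compound 3 `Cn1c(=O)c(=O)n(C2CCCC2)c2nc(N/N=C/c3ccco3)ncc21`: 72200 nM

All three numbers lie within the usual scatter of one another. Among the measured compounds shown here, compound 3 is separated from compound 1 by a 1.5-fold higher number from compound 1 to compound 3 (0.18 log units; within the scatter) and from compound 2 by a 1.2-fold lower number from compound 2 to compound 3 (0.07 log units; within the scatter); no compound can be told apart from the others on these numbers.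

The next member is compound 4 `Cn1c(=O)c(=O)n(C2CCCC2)c2nc(N/N=C/c3ccc(F)cc3Br)ncc21`. Its change against compound 3 is 2-bromo-4-fluorophenyl in place of furan-2-yl on a carbon with a double bond to nitrogen. The measured steps that bear on this place are the swaps of the aromatic group on the carbon with a double bond to nitrogen: a 1.5-fold higher number from compound 1 to compound 3 (0.18 log units; within the scatter), a 1.8-fold higher number from compound 1 to compound 2 (0.25 log units; within the scatter) and a 1.2-fold lower number from compound 2 to compound 3 (0.07 log units; within the scatter), each within the scatter. Phenyl, a substituted phenyl and furan-2-yl at this position give numbers that cannot be distinguished, so a further aryl swap is expected to give no step beyond the scatter in this assay.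

For compound 4 the expected step is a 1.2-fold lower number from compound 3 to compound 4 (0.08 log units; within the scatter). Compound 4 is therefore estimated at 60000 nM, with a range from 25000 nM to 140000 nM.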

Compound 4, half-maximal inhibitory concentration: 9250 nM
Beside the measured number, compound 4's estimate is 6.5-fold (0.81 log units) above it, outside the stated range (below it).
By their numbers in this assay, from the lowest: compound 4; then compounds 1, 3 and 2 (each within the scatter of the next).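

In this assay the aromatic group on the carbon with a double bond to nitrogen is no longer silent: 2-bromo-4-fluorophenyl gives a 7.8-fold lower number from compound 3 to compound 4 (0.89 log units; beyond the scatter) and a 9.2-fold lower number from compound 2 to compound 4 (0.96 log units; beyond the scatter) and also a 5.2-fold lower number from compound 1 to compound 4 (0.72 log units; beyond the scatter) with all three beyond the scatter, whereas swaps among phenyl, 3-fluoro-4-hydroxyphenyl and furan-2-yl stayed within it. Compound 4 alone separates from the rest of the series, although these steps remain modest in size. No measurement shown accounts for this change in the number.

Whether the step needs both halogens stays open, since 2-bromophenyl and 4-fluorophenyl do not appear among these compounds. Also open, going by these compounds, is how an amine or a carboxylic acid on the aromatic group would read in this assay here.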